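The source may hold more compounds than are shown below. What is called first, only, known or untested is meant among the compounds shown, and "the series" means these compounds.

For the measured compounds named here, compound 1, `Cc1cc(C)c(-c2csc(NC(=O)c3ccc([N+](=O)[O-])o3)n2)c(C)c1`, is the only member of this small set with a recorded number: in an ADME assay on Vero cells (Chlorocebus sabaeus) for cytotoxicity, read by MTT assay, with a stated time of 72 h (a higher number here means a weaker inhibitor, a lower number a stronger inhibitor), compound 1 gives 30400 nM. Compound 2, `CC(C)(C)OC(=O)Nc1cccc(-c2csc(NC(=O)c3ccc([N+](=O)[O-])o3)n2)c1`, shares the same core but carries a (tert-butoxycarbonyl)amino group on its aryl ring, and in this assay compound 2 is recorded as "not determined" (no result reported), so there is no single number on which it stands. Compound 3, `O=C(Nc1nc(-c2cccc(NS(=O)(=O)Cc3ccccc3)c2)cs1)c1ccc([N+](=O)[O-])o1`, differs from compound 2 in one place: benzylsulfonyl in place of tert-butoxycarbonyl on a nitrogen on an aromatic ring. Going by the values given here, with no measured step between compound 2 and any other compound in this assay, nothing in the data points to a direction for the change from compound 2 to compound 3, and the only anchor is compound 1 with 30400 nM. Compound 3 is therefore expected to land in the same weak region in this assay, around 25000 nM, within a range of 8000 nM to 80000 nM.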

Compound 3, half-maximal inhibitory concentration: 59300 nM
Estimate against measurement, compound 3: 2.4-fold (0.38 log units) below, and the stated range covers the measured number.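

No step can be read from the new result, as compound 2 offers no single number in this assay to set against compound 3. The compounds shown leave open what the change from (tert-butoxycarbonyl)amino to (benzylsulfonyl)amino does here. No evidence bears on the result.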